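The source may report more compounds than this note shows. Statements on the series, on what has been measured and on what is new or still open speak of the compounds shown alone.

Measured so far in a functional assay on HeLa cells (Homo sapiens) for cytotoxicity, read by MTT assay, with a stated time of 72 h; a lower number here means a stronger inhibitor, a higher number a weaker inhibitor:
- compound 1 `O=C(Nc1nnc(-c2cccc(O)c2O)s1)c1ccccc1`: 21800 nM
- compound 2 `O=C(Nc1nnc(-c2cccc(O)c2O)s1)C1CCCCC1`: 91600 nM
- compound 3 `CC(=O)Nc1nnc(-c2ccc(O)c(O)c2)s1`: 125000 nM

Compound 1 stands lowest of the three numbers in this assay; compound 2 is nearest and compound 3 furthest. Among the compounds with values here, the only single-point step recorded is a 4.2-fold higher number from compound 1 to compound 2 (0.62 log units; beyond the scatter), which shows that exchanging the ring on the carbonyl carbon costs potency. Compound 3 differs from compound 1 in more than one place, so its value is noted without a step.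

Compound 4 `O=C(COc1ccccc1)Nc1nnc(-c2cccc(O)c2O)s1` carries a different group at the same position: phenoxymethyl in place of phenyl on a carbonyl carbon. The aromatic ring is kept but set one atom further from the carbonyl. Going by the step from compound 1 to compound 2, a small weakening is expected, a 1.8-fold higher number from compound 1 to compound 4 (0.26 log units; within the scatter), as the estimated step. Compound 4 is thus expected to give about 40000 nM, estimated within 15000 nM to 110000 nM.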

Compound 4, half-maximal inhibitory concentration: 117000 nM
Beside the measured number, compound 4's estimate is 2.9-fold (0.47 log units) below it; the whole stated range lies below it.
By their numbers in this assay, from the lowest: compound 1; then compounds 2, 4 and 3 (each within the scatter of the next).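

In this assay, an aromatic ring on the carbonyl carbon is not enough to hold the number of compound 1: phenoxymethyl in place of phenyl gives a 5.4-fold higher number from compound 1 to compound 4 (0.73 log units; beyond the scatter). Phenoxymethyl and cyclohexyl cannot be told apart, with a 1.3-fold higher number from compound 2 to compound 4 (0.11 log units; within the scatter), so among these three groups only the directly attached phenyl stands apart. No available evidence accounts for this difference.

The compounds shown do not separate the added oxygen from the longer link to the ring, which a benzyl group would address. From the compounds shown here alone, how a pyridyl group or a substituted phenyl would read at this position also stays open.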